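Ester versus Acid at the Limit of a Weak Series

The compounds below may be only part of what the source reports. "The series", "measured", "known", "first", "only" and "open" are said of these compounds alone.

Compound 1 `CC#CCn1c(N2CCC[C@@H](N)C2)cc(=O)n(Cc2ccc(F)c(C(=O)OC)c2)c1=O`: > 100 nM
Compound 2 `CC#CCn1c(N2CCC[C@@H](N)C2)cc(=O)n(Cc2cc(C(=O)O)ccc2Br)c1=O`: > 100 nM
Compound 3 `CC#CCn1c(N2CCC[C@@H](N)C2)cc(=O)n(Cc2ccc(Br)c(C(=O)O)c2)c1=O`: > 100 nM

Compound 3 `CC#CCn1c(N2CCC[C@@H](N)C2)cc(=O)n(Cc2ccc(Br)c(C(=O)O)c2)c1=O` stands at the limit of an assay on isolated protein for inhibition of Dipeptidyl peptidase 9 (Homo sapiens), read by fluorescence, with stated times of 15 min and 20 min; on this read-out higher numbers stand for weaker inhibition and lower numbers for stronger inhibition: its value of > 100 nM is a limit of the assay and not a number. The same holds for the other two compounds shown, as the limit of > 100 nM in this assay, at which 3 of the 3 values shown sit, records. Compound 2 `CC#CCn1c(N2CCC[C@@H](N)C2)cc(=O)n(Cc2cc(C(=O)O)ccc2Br)c1=O` gives only a limit, > 100 nM. Compound 1 `CC#CCn1c(N2CCC[C@@H](N)C2)cc(=O)n(Cc2ccc(F)c(C(=O)OC)c2)c1=O` likewise gives only a limit, > 100 nM. The one single-site step among them, a step that the two limits leave unreadable from compound 2 to compound 3, is therefore unreadable, and nothing shown tells how large any move in this series really is.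

Compound 4 `CC#CCn1c(N2CCC[C@@H](N)C2)cc(=O)n(Cc2ccc(Br)c(C(=O)OC)c2)c1=O` differs from compound 3 by methyl in place of hydrogen on an oxygen next to a carbonyl group; cut one bond further out, this reads carboxy to methoxycarbonyl. Among the measured compounds shown here, no measured step bears on this exchange, so no size or direction can be drawn from the data. Given that every compound shown, including compound 3, sits at the limit, compound 4 is expected to stay there as well, with the step that the limit leaves unreadable from compound 3 to compound 4 expected to be no more than the scatter. The estimate for compound 4 is 300 nM, in the range 100 nM to 3000 nM.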

Compound 4, half-maximal inhibitory concentration: > 100 nM
Compound 4: only a limit was reported; the forecaster's own chance of this, stated with the estimate: 80%; the middle value lies beyond the limit too.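

In this assay compound 4 gives > 100 nM, a limit of the assay and not a number. Among the compounds shown here, neither the step from compound 3 to compound 4 nor the one from compound 1 to compound 4 can be read. The compounds shown leave open how strongly any of them actually inhibits, as all stand at one limit: the limit of > 100 nM in this assay, at which 4 of the 4 values shown sit.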